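This account rests on a few compounds, and the source may have more. Where it says the series, first, only, none or still open, it means among the compounds named here.

Measured so far:
compound 1 `Cc1ccnc(NC(c2ccc(F)cc2)c2ccc3cccnc3c2O)c1` — 140 nM
compound 2 `Cc1ccnc(NC(c2ccc3cccnc3c2O)c2c(Cl)cccc2Cl)c1` — limit only

Compound 2 `Cc1ccnc(NC(c2ccc3cccnc3c2O)c2c(Cl)cccc2Cl)c1` gives in an assay for inhibition of protein disulfide-isomerase (Homo sapiens), with a stated time of 1 h (on this read-out higher numbers stand for weaker inhibition and lower numbers for stronger inhibition), only a limit, > 40000 nM; no number is known for it. Compound 1 `Cc1ccnc(NC(c2ccc(F)cc2)c2ccc3cccnc3c2O)c1`, which differs from it only in the aryl group, gives 140 nM in this assay. Within the data shown here, the single measured step is an at least 280-fold higher number from compound 1 to compound 2 (2.45 log units; beyond the scatter), the value for compound 2 sitting at the limit of > 40000 nM in this assay, at which 1 of the 2 values shown sits.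

The next compound, compound 3 `Cc1ccnc(NC(c2ccc([N+](=O)[O-])cc2)c2ccc3cccnc3c2O)c1`, differs from compound 2 by 4-nitrophenyl in place of 2,6-dichlorophenyl on a saturated chain carbon bound to an aromatic carbon and a nitrogen on an aromatic ring. The entering 4-nitrophenyl, like the 4-fluorophenyl of compound 1, carries a single substituent, whereas the leaving 2,6-dichlorophenyl carries two. Among the measured compounds shown here, the one measured step bears directly on this change in reverse: removing 2,6-dichlorophenyl in favour of a singly substituted phenyl is expected to recover much of what was lost from compound 1 to compound 2.

Compound 3 is therefore expected to give a number rather than a limit, with an at least 66-fold lower number from compound 2 to compound 3 (1.82 log units; beyond the scatter) expected. The estimate for compound 3 is 600 nM, between 100 nM and 8000 nM.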

Compound 3, half-maximal inhibitory concentration: 530 nM
For compound 3 the middle estimate is 1.1-fold (0.05 log units) above the measured one; low and high end bracket the measured number.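

The change from 2,6-dichlorophenyl to 4-nitrophenyl on this saturated chain carbon brings back a measurable number, an at least 75-fold lower number from compound 2 to compound 3 (1.87 log units; beyond the scatter), so the collapse seen in compound 2 does not extend to every change of aryl group at this place. The nitro in place of fluoro on an aromatic carbon costs far less, a 3.8-fold higher number from compound 1 to compound 3 (0.58 log units; beyond the scatter), so both singly substituted phenyl groups shown keep a measurable number in this assay. Compound 2 still gives only a limit, so the size of the recovery has a floor and no exact value: the limit of > 40000 nM in this assay, at which 1 of the 3 values shown sits.

From the compounds shown here alone, whether the loss in compound 2 follows from having two chlorines or from where they sit in 2,6-dichlorophenyl remains open, and 4-chlorophenyl and 2-chlorophenyl would separate the two. Going by these compounds, how an unsubstituted phenyl, a 4-aminophenyl or a 4-carboxyphenyl would compare with compound 1 also remains open.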